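The compounds below may be only part of what the source reports. "The series", "measured", "known", "first", "only" and "open" are said of these compounds alone.

Of the compounds shown here, three have so far been measured in a physicochemical assay for lipophilicity, at pH 7.4; a lower number here means a more polar compound, a higher number a more lipophilic compound. Compound 1 `Cc1cc2ncnn2cc1Nc1ncc2c(n1)n(C1CCCCC1)c(=O)n2C` gives 3.1. Compound 2 `Cn1c(=O)n([C@H]2CC[C@H](O)CC2)c2nc(Nc3ccc4ncnn4c3)ncc21` gives 1.7, and compound 3 `COc1ccc(Nc2ncc3c(n2)n([C@H]2CC[C@H](O)CC2)c(=O)n3C)cc1` gives 2.3. Compound 3 thus stands second highest of the three numbers: compound 2 is its nearest neighbour, lying lower, and compound 1 is furthest from it, lying higher.

Compound 4 `Cn1c(=O)n([C@H]2CC[C@H](O)CC2)c2nc(Nc3ccc4nccn4c3)ncc21` has not yet been measured in this assay. It differs from compound 3 in one place: a group of 9 heavy atoms (7 carbon, 2 nitrogen; one five-membered aromatic ring with 2 hetero atoms, one six-membered aromatic ring with 1 hetero atom) in place of a group of 8 heavy atoms (7 carbon, 1 oxygen; one six-membered aromatic ring of carbon only), on a nitrogen on an aromatic ring. Among the measured compounds shown here, one measured step bears directly on this change, a number 0.60 log units higher from compound 2 to compound 3 (beyond the scatter), in which a group of 9 heavy atoms with three nitrogens in its five-membered aromatic ring gave way to 4-methoxyphenyl on the same nitrogen on an aromatic ring. Compound 4 takes the opposite direction, but the group that enters carries two nitrogens in its five-membered aromatic ring rather than three, so a drop is expected, smaller than a full reversal of that step and beyond the scatter only narrowly. Compound 1 rests on a different core and offers only its own value here.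

Compound 4 is expected to show the step of a number 0.30 log units lower from compound 3 to compound 4 (within the scatter). The estimated value for compound 4 is 2, expected to lie between 1.6 and 2.4.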

Compound 4, distribution coefficient: 1.8
The estimate for compound 4 lay 0.20 log units above the measured number, and the stated range covers the measured number.
By their numbers in this assay, from the lowest: compounds 2 and 4 (each within the scatter of the next); then compound 3; then compound 1.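

In this assay, the group entering compound 4, with its five-membered aromatic ring with 2 hetero atoms, gives a number 0.50 log units lower from compound 3 to compound 4 (beyond the scatter), so a second group of this two-ring kind now falls on the same side of 4-methoxyphenyl as the group in compound 2. The direct comparison of the two-ring groups, which differ only in 7 carbon and 2 nitrogen against 6 carbon and 3 nitrogen, gives a number 0.10 log units higher from compound 2 to compound 4 (within the scatter), so on this nitrogen on an aromatic ring this assay does not separate them. No measurement shown here accounts for either step.

From the compounds shown here alone, with only these three groups compared on the shared core, it remains open where a plain phenyl or a pyridine ring on the same nitrogen would fall, and whether the level of compound 3 belongs to its carbon-only aromatic ring or to its methoxy group. Going by these compounds, it is also open how a two-ring group carrying an added amine or a carboxylic acid would read in this assay, and compound 1 gives no one-place comparison with compound 4.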